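Bombesin receptor subtype-3 agonists: aryl swap on the benzyl arm

The source may hold more compounds than are shown below. What is called first, only, known or untested is meant among the compounds shown, and "the series" means these compounds.

Measured so far:
compound 1 `O=C(O)c1ccccc1-c1ccc(CCc2ncc(CC3CCCCC3)[nH]2)cc1` — 41 nM
compound 2 `COc1cccc(Cc2cnc(CCc3ccc(-c4ccccc4C(=O)O)cc3)[nH]2)c1` — 4120 nM

In an in vitro functional assay on cells for agonist activity at Bombesin receptor subtype-3 (Homo sapiens), read by luminescence and calcium flux (on this read-out higher numbers stand for an effect only at larger amounts of compound and lower numbers for an effect already at smaller amounts), compound 2 gives 4120 nM, the highest of the two numbers; its nearest neighbour is compound 1, which gives 41 nM. Compound 3 `O=C(O)c1ccccc1-c1ccc(CCc2ncc(Cc3ccccc3Cl)[nH]2)cc1` differs from compound 2 by 2-chlorophenyl in place of 3-methoxyphenyl on a saturated chain carbon bound to an aromatic carbon. For the measured compounds named here, only one measured step touches this position, a 100-fold higher number from compound 1 to compound 2 (2.00 log units; beyond the scatter), but it exchanged a saturated ring for an aryl, not one aryl for another, so it offers little guidance for this change. A modest drop in the number is expected for compound 3, a 2.7-fold lower number from compound 2 to compound 3 (0.44 log units; beyond the scatter), with wide uncertainty. Compound 3 is therefore estimated at 1500 nM, between 250 nM and 9000 nM.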

Compound 3, half-maximal effective concentration: 292 nM
For compound 3 the middle estimate is 5.1-fold (0.71 log units) above the measured one; low and high end bracket the measured number.
By their numbers in this assay, from the lowest: compound 1; then compound 3; then compound 2.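

In this assay the identity of the aryl group at this position matters: 2-chlorophenyl in place of 3-methoxyphenyl gives a 14-fold lower number from compound 2 to compound 3 (1.15 log units; beyond the scatter) in a large step. Even so, an aryl group here does not match cyclohexyl, with a 7.1-fold higher number from compound 1 to compound 3 (0.85 log units; beyond the scatter) in a modest step. No evidence at hand accounts for either step. As far as these compounds go, what an unsubstituted phenyl or a 3-chlorophenyl would give stays open. The gain therefore cannot yet be assigned to the chlorine, to the loss of the methoxy, or to where the substituent sits.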